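Sulfonamide aryl swap in the bromotriazole series

This account rests on a few compounds, and the source may have more. Where it says the series, first, only, none or still open, it means among the compounds named here.

Measured compounds in an assay on HEK293 cells for inhibition of solute carrier family 22 member 12 (Homo sapiens); a lower number here means a stronger inhibitor, a higher number a weaker inhibitor:
- compound 1 `O=C(O)CSc1nnc(Br)n1Cc1ccc(Br)c2ccccc12`, 94 nM
- compound 2 `Oc1c(Br)cc(CSc2nnc(Br)n2Cc2ccc(Br)c3ccccc23)cc1Br`, 119000 nM
- compound 3 `O=S(=O)(CSc1nnc(Br)n1Cc1ccc(Br)c2ccccc12)Nc1cc(Cl)cnc1Cl`, 2790 nM

Compound 3 stands second highest of the three numbers in this assay: compound 1 lies a step lower, compound 2 a larger step higher, both gaps beyond the scatter. Among the compounds with values here, the only step recorded between two measured compounds that differ in one place is a 1300-fold higher number from compound 1 to compound 2 (3.10 log units; beyond the scatter); it concerns the group on the saturated chain carbon bound to sulfur, not the sulfonamide nitrogen.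

Compound 4 `O=S(=O)(CSc1nnc(Br)n1Cc1ccc(Br)c2ccccc12)Nc1ccc(Br)nc1` differs from compound 3 by 6-bromopyridin-3-yl in place of 2,5-dichloropyridin-3-yl on a sulfonamide nitrogen. One six-membered aromatic ring with one hetero atom is replaced by another of the same kind, with one bromine entering where two chlorines leave; the donor and acceptor counts are unchanged. Within the data shown here, no measured step bears on this position, so the expectation rests only on the value of compound 3 and the fact that the change is confined to the aryl group on the sulfonamide nitrogen. A step of no more than the usual scatter in either direction is expected; the step from compound 3 to compound 4 is estimated as a 1.1-fold higher number from compound 3 to compound 4 (0.03 log units; within the scatter).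

Compound 4 is expected to give 3000 nM in this assay, within the range 800 nM to 12000 nM.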

Compound 4, half-maximal inhibitory concentration: 2200 nM
For compound 4 the middle estimate is 1.4-fold (0.13 log units) above the measured one, within the range that was stated.
By their numbers in this assay, from the lowest: compound 1; then compounds 4 and 3 (each within the scatter of the next); then compound 2.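

In this assay the swap on the sulfonamide nitrogen reads as a 1.3-fold lower number from compound 3 to compound 4 (0.10 log units; within the scatter), so 6-bromopyridin-3-yl and 2,5-dichloropyridin-3-yl cannot be told apart here. Within the data shown here, this is the first reading at this position, and it shows that one bromine can enter where two chlorines leave, with one six-membered aromatic ring with 1 hetero atom kept, without a change beyond the scatter; the only earlier step, on the saturated chain carbon bound to a sulfur, was much larger (a 1300-fold higher number from compound 1 to compound 2 (3.10 log units; beyond the scatter)). No measurement at hand speaks to why these two aryl groups read alike.

Still open, as far as these compounds go, is how far this flat reading extends on the sulfonamide nitrogen: a plain phenyl ring with no ring nitrogen, an unsubstituted pyridin-3-yl or a small alkyl group such as methyl would each test it. Among these compounds, the single step also changes the identity, number and placement of the halogens together, so the contribution of a lone chlorine or a lone bromine on the ring remains unresolved.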